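This account rests on a few compounds, and the source may have more. Where it says the series, first, only, none or still open, it means among the compounds named here.

Of the compounds shown here, three sharing one core have been measured, and they differ only in what sits on one aromatic carbon: hydrogen in compound 1 `CC1(/C=C/c2ccccc2)C=CC(=O)O1`, trifluoromethyl in compound 2 `CC1(/C=C/c2ccc(C(F)(F)F)cc2)C=CC(=O)O1` and fluoro in compound 3 `CC1(/C=C/c2ccc(F)cc2)C=CC(=O)O1`. In a functional assay on HT-29 cells (Homo sapiens) for inhibition, read by sulforhodamine B assay, with a stated time of 48 h (a higher number here means a weaker inhibitor of growth, a lower number a stronger inhibitor of growth), compound 1 gives 123000 nM, compound 2 gives 12300 nM and compound 3 gives 34900 nM, so compound 3 stands between the other two. Compound 4 `CC1(/C=C/c2ccc(O)cc2)C=CC(=O)O1` has hydroxy in place of fluoro on an aromatic carbon, para to a group of 9 heavy atoms: hydroxy in place of fluoro on an aromatic carbon. Among the compounds with values here, three measured steps bear on this change. Replacing hydrogen gave a 10-fold lower number from compound 1 to compound 2 (1.00 log units; beyond the scatter) and a 3.5-fold lower number from compound 1 to compound 3 (0.55 log units; beyond the scatter), while swapping the two fluorine-bearing groups gave a 2.8-fold higher number from compound 2 to compound 3 (0.45 log units; beyond the scatter). Within the data shown here, no measured compound carries hydroxy, so these steps only suggest the likely size. Since hydroxy contains no fluorine, the expectation leans back toward compound 1 at 123000 nM. A modest rise in the number is expected, estimated as a 2.1-fold higher number from compound 3 to compound 4 (0.33 log units; beyond the scatter). For compound 4 the estimated value is 75000 nM, with an expected range of 22000 nM to 220000 nM.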

Compound 4, concentration for total growth inhibition: 122000 nM
Compound 4: the middle estimate sits 1.6-fold (0.21 log units) below what was measured, within the range that was stated.
By their numbers in this assay, from the lowest: compound 2; then compound 3; then compounds 4 and 1 (each within the scatter of the next).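

Hydroxy in place of fluoro on this aromatic carbon gives a 3.5-fold higher number from compound 3 to compound 4 (0.54 log units; beyond the scatter) and hydroxy in place of trifluoromethyl gives a 9.9-fold higher number from compound 2 to compound 4 (1.00 log units; beyond the scatter) in this assay, so hydroxy does not share the lower numbers of the two fluorine-bearing groups. Set against hydrogen, the change reads a 1.0-fold lower number from compound 1 to compound 4 (0.00 log units; within the scatter), so in this assay hydroxy and hydrogen cannot be told apart at this position, and among these four compounds only the two carrying fluorine stand clearly lower, with no compound going against that. Nothing available explains this difference between the groups.

As far as these compounds go, it remains open whether a group without fluorine, such as an amine, a nitrile or a carboxylic acid, could also lower the number here. Methoxy is a further open case, as it would show whether capping the hydroxy oxygen with a methyl group changes the result.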